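The source may hold more compounds than are shown below. What is called first, only, known or untested is meant among the compounds shown, and "the series" means these compounds.

Three close relatives share one core and differ only in the aromatic group on a double-bonded chain carbon: compound 1 `O=C(COc1ccc(C(=O)/C=C/c2cccc(Cl)c2)cc1)N[C@H]1CCOC1=O`, compound 2 `O=C(COc1ccc(C(=O)/C=C/c2ccc(Cl)cc2Cl)cc1)N[C@H]1CCOC1=O` and compound 3 `O=C(COc1ccc(C(=O)/C=C/c2ccc(F)cc2)cc1)N[C@H]1CCOC1=O`. In a functional assay on MGC-803 cells (Homo sapiens) for antiproliferative activity, read by MTT assay, with a stated time of 72 h (on this read-out higher numbers stand for weaker inhibition and lower numbers for stronger inhibition), compound 1 gives 29100 nM. In this assay compound 2 gives 26500 nM, and the two sit close together, with a 1.1-fold lower number from compound 1 to compound 2 (0.04 log units; within the scatter). Compound 3 reads > 64000 nM, which is a limit of the assay and not a number.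

The steps leading to compound 3 are an at least 2.1-fold higher number from compound 1 to compound 3 (0.34 log units; beyond the scatter) and an at least 2.4-fold higher number from compound 2 to compound 3 (0.38 log units; beyond the scatter), so it stands on the weak side of both relatives. Compound 4 `O=C(COc1ccc(C(=O)/C=C/c2cccc(Br)c2)cc1)N[C@H]1CCOC1=O` carries 3-bromophenyl in place of 4-fluorophenyl (3-bromophenyl in place of 4-fluorophenyl on a double-bonded chain carbon bound to a double-bonded chain carbon). This exchange happens at the same place as those two measured steps, but it leaves the 4-fluorophenyl group instead of arriving at it. The best guide is compound 1, which holds 3-chlorophenyl and gives 29100 nM, so compound 4 is expected to fall near it. A modest step toward a lower number is therefore expected in this assay, and the expected size is an at least 2.3-fold lower number from compound 3 to compound 4 (0.37 log units; beyond the scatter). For compound 4 the estimate is 27000 nM, with an expected range from 12000 nM to 60000 nM.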

Compound 4, half-maximal inhibitory concentration: 11900 nM
Compound 4: the middle estimate sits 2.3-fold (0.36 log units) above what was measured; measured number outside the range, below it.
By their numbers in this assay, from the lowest: compound 4; then compounds 2 and 1 (each within the scatter of the next). At a limit, above all of these: compound 3.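

Until now, the two chlorinated compounds sat within the scatter of each other, and only compound 3 stood apart. Here a single-atom exchange on the aromatic ring moves the number beyond the scatter in this assay (a 2.4-fold lower number from compound 1 to compound 4 (0.39 log units; beyond the scatter)), so this part of the molecule responds to which halogen it carries, not merely to whether one is there. Compound 4 also separates from the 2,4-dichlorophenyl compound (a 2.2-fold lower number from compound 2 to compound 4 (0.35 log units; beyond the scatter)) and from the 4-fluorophenyl compound (an at least 5.3-fold lower number from compound 3 to compound 4 (0.73 log units; beyond the scatter)), which gives it the lowest number of the four, but that last step shows only a minimum size because compound 3 reads at a limit of the assay, not at a number: (the limit of > 64000 nM in this assay, at which 1 of the 4 values shown sits).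

A 4-bromophenyl and a 3-fluorophenyl group would help separate the effect of the halogen from that of its place on the ring, since compounds 3 and 4 differ in both. A 3-methoxyphenyl or 3-aminophenyl group would show whether a halogen is needed at all for a number as low as that of compound 4.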